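Swapping the aryl group on the sulfonyl sulfur once more

The compounds below may be only part of what the source reports. "The series", "measured", "known", "first", "only" and "open" are said of these compounds alone.

Two compounds share a core built from a chalcone-like fragment joined to a piperazine that carries a sulfonyl group, and they differ only in the aryl ring on that sulfonyl sulfur. Compound 1 `O=C(/C=C/c1ccccc1)c1ccc(N2CCN(S(=O)(=O)c3ccc(Br)cc3)CC2)cc1` carries a 4-bromophenyl there and in a functional assay on the whole organism (strain Kunming) for inhibition, with Mus musculus as the target, with a stated time of 1 h, at a dose of 40 mg/kg by the oral route (a lower number here means less inhibition, a higher number more inhibition at the dose given (going by the name of the read-out)), compound 1 gives 47.4%. Compound 2 `Cc1cc(C)c(S(=O)(=O)N2CCN(c3ccc(C(=O)/C=C/c4ccccc4)cc3)CC2)c(C)c1` carries a 2,4,6-trimethylphenyl instead and in this assay compound 2 gives 55.5%. Going by the values given here, the single step between them, a number 8.1 percentage points higher from compound 1 to compound 2 (within the scatter), means the two numbers cannot be told apart by this measurement.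

Compound 3 `O=C(/C=C/c1ccccc1)c1ccc(N2CCN(S(=O)(=O)c3ccc(OC(F)(F)F)cc3)CC2)cc1` is the next variation: 4-(trifluoromethoxy)phenyl in place of 2,4,6-trimethylphenyl on a sulfonyl sulfur. Among the compounds with values here, the only measured step that touches this position is the one from compound 1 to compound 2, and it stayed within the scatter. Nothing measured speaks directly for a 4-(trifluoromethoxy)phenyl, so the expectation rests on that single step and on the shared core.

Compound 3 is therefore expected to give about 50% in this assay, within a range from 33% to 67%. The estimated step of a number 5.5 percentage points lower from compound 2 to compound 3 (within the scatter) is expected to fall within the scatter.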

Compound 3, a percentage reported as inhibition, in the whole organism at one dose (the size of the read-out at that dose, not a potency): 47.4%
Compound 3: middle estimate off by 2.6 percentage points, on the high side; the measured number falls inside the stated range.
By their numbers in this assay, from the lowest: compounds 1, 3 and 2 (each within the scatter of the next).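

In this assay the change to 4-(trifluoromethoxy)phenyl on the sulfonyl sulfur gives a number 8.1 percentage points lower from compound 2 to compound 3 (within the scatter) and the exchange of bromo for trifluoromethoxy on an aromatic carbon gives no change at the digits printed from compound 1 to compound 3 (within the scatter) so the three aryl groups now seen at this position cannot be told apart by this measurement. The earlier comparison rested on one step between two groups, whereas this position now has three groups with different atoms on the ring: bromine in compound 1, carbon only in the 2,4,6-trimethylphenyl of compound 2, and oxygen and fluorine in the 4-(trifluoromethoxy)phenyl of compound 3, and none of the steps among them lies beyond the scatter. No outside measurement is available to explain why these compounds read alike.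

All three groups shown on the sulfur are substituted phenyl rings, so it remains open whether a phenyl ring carrying an amine or a carboxylic acid, or a longer alkyl chain in place of the ring, would be told apart from them. Changes elsewhere in the shared core, such as on the far phenyl ring, also remain open.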